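The source may hold more compounds than are shown below. What is called first, only, known or untested is meant among the compounds shown, and "the series" means these compounds.

Working notes on the series. In a physicochemical assay for solubility, with a stated time of 20 h, at pH 6.8 (a higher number here means a more soluble compound, a lower number a less soluble compound), compound 1 `O=S1(=O)Cc2nc(-c3cc(F)c(Cl)cc3F)nc(N3CCC(CO)CC3)c2C1` gives 16000 nM and compound 2 `NC(=O)CCC1CCN(c2nc(-c3cc(F)c(Cl)cc3F)nc3c2CS(=O)(=O)C3)CC1` gives 8000 nM. For the measured compounds named here, compound 2 stands lowest of the two numbers so far, with compound 1 its nearest neighbour; the step of a 2.0-fold lower number from compound 1 to compound 2 (0.30 log units; within the scatter) shows that exchanging the group on the side chain of the saturated ring left the result within the scatter.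

Compound 3 `CNC(=O)C1CCN(c2nc(-c3cc(F)c(Cl)cc3F)nc3c2CS(=O)(=O)C3)CC1` carries methylcarbamoyl in place of 2-carbamoylethyl on a saturated ring carbon. Going by the values given here, the only measured step that bears on this change is the one from compound 1 to compound 2, which swapped one group for another at the same saturated ring position and gave a number within the scatter. On that basis no step beyond the scatter is expected in this assay for compound 3, in either direction.

For compound 3 the expected step of no change at the digits printed from compound 2 to compound 3 (within the scatter) is therefore small. Compound 3 is estimated at 8000 nM, with a range from 3000 nM to 20000 nM.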

Compound 3, solubility: 11000 nM
Compound 3: middle estimate off by 1.4-fold (0.14 log units), on the low side; measured number inside the range.
By their numbers in this assay, from the lowest: compounds 2, 3 and 1 (each within the scatter of the next).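

Working notes, continued. On the saturated ring carbon three ring bonds from the ring nitrogen, methylcarbamoyl in place of 2-carbamoylethyl gives a 1.4-fold higher number from compound 2 to compound 3 (0.14 log units; within the scatter) in this assay and so adds a second amide-bearing group to the comparison. Methylcarbamoyl in place of hydroxymethyl gives a 1.5-fold lower number from compound 1 to compound 3 (0.16 log units; within the scatter) and thus extends the earlier single comparison: all three pairs among hydroxymethyl, 2-carbamoylethyl and methylcarbamoyl now lie within the scatter at this position. No measurement is at hand that explains this result.

The compounds shown leave open whether an amine or a carboxylic acid on this ring carbon would give a step beyond the scatter. As far as these compounds go, it also remains open whether a longer chain ending in an amide would stay within the scatter of these three compounds.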